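Iodo on compound 3: notes on the amide series

This account rests on a few compounds, and the source may have more. Where it says the series, first, only, none or still open, it means among the compounds named here.

In a functional assay on MDA-MB-468 cells (Homo sapiens) for antiproliferative activity (on this read-out higher numbers stand for weaker inhibition and lower numbers for stronger inhibition), compound 1 (`Nc1ccc(-c2nc3ccccc3s2)cc1I`) gives < 1 nM as a limit of the assay. Compound 2 (`CC(=O)Nc1ccc(-c2nc3ccccc3s2)cc1I`) gives > 100 nM as a limit too. Compound 3 (`O=C(CCl)Nc1ccc(-c2nc3ccccc3s2)cc1`) gives > 100 nM as a limit, not a number. That places it at the limit of > 100 nM in this assay, at which 2 of the 3 values shown sit, so its true position is open.

Compound 4 (`O=C(CCl)Nc1ccc(-c2nc3ccccc3s2)cc1I`) has iodo in place of hydrogen on an aromatic carbon of compound 3: iodo in place of hydrogen on an aromatic carbon. Within the data shown here, no measured pair isolates this change. The nearest evidence is an at least 100-fold higher number from compound 1 to compound 2 (2.00 log units; beyond the scatter), a large step for acetyl in place of hydrogen on a nitrogen on an aromatic ring. Compound 2 thus carries both iodo and an acylated nitrogen, yet its reading is a limit on the weak side, as is that of compound 3.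

The expected result is a step that the limit leaves unreadable from compound 3 to compound 4, with no change beyond the scatter anticipated. For compound 4 the estimate is 150 nM, with an expected range from 30 nM to 1000 nM in this assay, and a report as a limit is likely.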

Compound 4, half-maximal inhibitory concentration: > 10 nM
Compound 4: a limit, no number; the forecaster's own chance of this, stated with the estimate: 70%; the middle value lies beyond the limit too.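

With iodo held in place, (chloromethyl)carbonyl in place of hydrogen on the nitrogen gives an at least 10-fold higher number from compound 1 to compound 4 (1.00 log units; beyond the scatter) in this assay, and acetyl in the same place gives an at least 100-fold higher number from compound 1 to compound 2 (2.00 log units; beyond the scatter), so two different acyl groups on that nitrogen now go the same way. Compound 4 gives > 10 nM, which is a limit and not a number. The steps to compound 4 from compound 3 and from compound 2 cannot be read, so neither the iodo change nor the chloro change has a size here.

From the compounds shown here alone, whether iodo contributes anything on the amide series therefore stays open. Also open, going by these compounds, is whether iodo counts on the free amine, where the amine with hydrogen, bromo or methyl in place of iodo would give a readable comparison with compound 1.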